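The source may report more compounds than this note shows. Statements on the series, on what has been measured and on what is new or still open speak of the compounds shown alone.

Of the compounds shown here, three sharing one core have been measured in a functional assay on SF-539 cells (Homo sapiens) for cytotoxicity, read by sulforhodamine B assay, with a stated time of 48 h, tested at 0.1 uM; a higher number here means a weaker effect of the compound at the concentration tested, a lower number a stronger effect. Compound 1 `COc1cc(-c2cc(/C=C/C(=O)c3ccc(Cl)c(Cl)c3)[nH]n2)cc(OC)c1OC` gives 94% in this assay. Compound 2 `COc1ccc(-c2cc(/C=C/C(=O)c3ccc(N)cc3)[nH]n2)cc1OC` gives 97%, and compound 3 `COc1ccc(-c2cc(/C=C/C(=O)c3ccc(N)cc3)[nH]n2)cc1` gives 97%. The number for compound 1 differs from those of compound 2 and compound 3 only within the usual scatter, so the three stand together with little effect at this concentration. Among the compounds with values here, the one step among them, no change at the digits printed from compound 2 to compound 3 (within the scatter), shows that a hydrogen in place of a methoxy on an aromatic carbon leaves the read-out where it was.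

Compound 4 `COc1ccc(C(=O)/C=C/c2cc(-c3cc(OC)c(OC)c(OC)c3)n[nH]2)cc1OC` differs from compound 1 by 3,4-dimethoxyphenyl in place of 3,4-dichlorophenyl on a carbonyl carbon. Within the data shown here, no measured pair exchanges a chlorine for a methoxy on the aryl attached to the carbonyl, so the only guidance is that the methoxy change from compound 2 to compound 3 and the differing aryl groups of compounds 1 to 3 all sit within the scatter. Compound 4 is therefore expected to give about 96% in this assay, within 86% to 103%, the estimated step of a number 2 percentage points higher from compound 1 to compound 4 (within the scatter) being none beyond the scatter.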

Compound 4, a percentage reported as activity, at one concentration (the size of the read-out at that concentration, not a potency): 98%
Beside the measured number, compound 4's estimate is 2 percentage points below it, within the range that was stated.
By their numbers in this assay, from the lowest: compounds 1, 2, 3 and 4 (each within the scatter of the next).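

In this assay, putting 3,4-dimethoxyphenyl in place of 3,4-dichlorophenyl on a carbonyl carbon gives a number 4 percentage points higher from compound 1 to compound 4 (within the scatter) and so stays within the scatter. Within the data shown here, this is the first exchange in a single place on the aryl attached to the carbonyl, and the read-out holds even though the entering group has 2 hydrogen-bond acceptors where the leaving group has 0 and 10 heavy atoms where the leaving group has 8. Nothing available offers an explanation for this result.

On these data alone, it remains open whether a carboxylic acid or a morpholine ring on this aryl would move the read-out beyond the scatter. As far as these compounds go, since all four compounds sit close together at the single concentration tested, it also remains open whether these two aryl groups would differ at other concentrations.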